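Ethyl for methyl on the azole nitrogen, two cores compared

This account rests on a few compounds, and the source may have more. Where it says the series, first, only, none or still open, it means among the compounds named here.

Values below come from an in vitro functional assay on cells (Fibroblast) for agonist activity at Alpha-1A adrenergic receptor (Homo sapiens); a lower number here means that less compound is needed, a higher number that more compound is needed for the effect.
compound 1 `Cn1ncnc1-c1ccccc1NCC1=NCCN1`: 2 nM
compound 2 `CCn1ncnc1-c1ccccc1NCC1=NCCN1`: 1.26 nM
compound 3 `Cn1cc(-c2ccccc2NCC2=NCCN2)cn1`: 398 nM

Compound 1 and compound 2 differ by methyl in place of hydrogen on a saturated chain carbon bound to an aromatic nitrogen, and the step is a 1.6-fold lower number from compound 1 to compound 2 (0.20 log units; within the scatter). The core of compound 3 differs from that of compound 1 by 1-methyl-1H-pyrazol-4-yl in place of 1-methyl-1H-1,2,4-triazol-5-yl on an aromatic carbon; that step is a 200-fold higher number from compound 1 to compound 3 (2.30 log units; beyond the scatter), so compound 3 sits far from both others.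

Compound 4 `CCn1cc(-c2ccccc2NCC2=NCCN2)cn1` is not yet measured. It differs from compound 3 by methyl in place of hydrogen on a saturated chain carbon bound to an aromatic nitrogen, the same change as between compound 1 and compound 2, made on the weaker core. Among the compounds with values here, only one earlier instance exists, and it stayed within the scatter, so compound 4 is expected to show a 1.3-fold lower number from compound 3 to compound 4 (0.12 log units; within the scatter), resting on a 1.6-fold lower number from compound 1 to compound 2 (0.20 log units; within the scatter). The estimate for compound 4 is 300 nM, expected between 120 nM and 750 nM.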

Compound 4, half-maximal effective concentration: < 100000 nM
Compound 4 ended at the assay's limit; the forecaster's own chance of this, stated with the estimate: 0%; the middle value does not contradict the limit.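

Within the data shown here, compound 4 gives < 100000 nM, which is a limit of the assay and not a number, so no step from compound 3 to compound 4 can be read. The compounds shown leave open whether methyl to ethyl alters the number on the core of compound 3 at all.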